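From pyridin-3-yl to pyridin-4-yl on the shared core

This account rests on a few compounds, and the source may have more. Where it says the series, first, only, none or still open, it means among the compounds named here.

Compound 1 `C1=C(/C=C/c2ccncc2)COc2ccccc21` gives 75000 nM
Compound 2 `C1=C(/C=C\c2cccnc2)COc2ccccc21` gives 37500 nM

For the measured compounds named here, in an ADME assay on HeLa cells (Homo sapiens) for cytotoxicity, read by XTT assay, with a stated time of 3 days (a higher number here means that more compound is tolerated, a lower number that less compound is tolerated), compound 2 gives 37500 nM and so stands within the usual scatter of compound 1 at 75000 nM on the only two numbers known. Compound 3 `C1=C(/C=C\c2ccncc2)COc2ccccc21` carries pyridin-4-yl in place of pyridin-3-yl on a double-bonded chain carbon bound to a double-bonded chain carbon. Going by the values given here, no step between measured compounds is available to guide the size of this change. The expected change is a 1.3-fold higher number from compound 2 to compound 3 (0.12 log units; within the scatter) and nothing beyond the scatter in either direction. For compound 3 the estimated value is 50000 nM with an expected range from 22000 nM to 110000 nM in this measurement.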

Compound 3, half-maximal cytotoxic concentration: 50000 nM
Compound 3: middle estimate and measured number agree at the digits printed, and the stated range covers the measured number.
By their numbers in this assay, from the lowest: compounds 2, 3 and 1 (each within the scatter of the next).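

In this assay, pyridin-4-yl in place of pyridin-3-yl on a double-bonded chain carbon bound to a double-bonded chain carbon gives a 1.3-fold higher number from compound 2 to compound 3 (0.12 log units; within the scatter), and the double bond drawn Z rather than E gives a 1.5-fold lower number from compound 1 to compound 3 (0.18 log units; within the scatter). Neither change moves the number beyond the scatter, and the second comparison isolates the drawn geometry alone: the fact that compounds 1 and 3 differ only in the configuration as drawn. The compounds shown leave open whether an amine or a carboxylic acid in place of the pyridinyl group, or a longer chain carrying it, would move the number beyond the scatter.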